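Series notes: methyl in place of chloro, compound 4

The source may report more compounds than this note shows. Statements on the series, on what has been measured and on what is new or still open speak of the compounds shown alone.

Three compounds of the shared core have been run in a functional assay on A549 cells (Homo sapiens) for antiproliferative activity, read by MTT assay, with a stated time of 72 h; on this read-out lower numbers stand for stronger inhibition and higher numbers for weaker inhibition. Compound 1 `NS(=O)(=O)c1ccc(NC(=S)Nc2ccc3ncnc(Nc4ccc(F)c(Cl)c4)c3c2)cc1` returns only the limit > 40000 nM, not a number. Compound 2 `C#Cc1cccc(Nc2ncnc3ccc(NC(=S)Nc4ccc(S(N)(=O)=O)cc4)cc23)c1` likewise returns only the limit > 40000 nM. Compound 3 `NS(=O)(=O)c1ccc(NC(=S)Nc2ccc3ncnc(Nc4cccc(Cl)c4)c3c2)cc1` also returns only the limit > 40000 nM. Compound 3 therefore stands at the limit together with the two others, as recorded in the limit of > 40000 nM in this assay, at which 3 of the 3 values shown sit, and no ordering among the three can be read from this assay.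

Compound 4 `Cc1cccc(Nc2ncnc3ccc(NC(=S)Nc4ccc(S(N)(=O)=O)cc4)cc23)c1` differs from compound 3 by methyl in place of chloro on an aromatic carbon. The measured steps that touch the same aromatic ring are a step that the two limits leave unreadable from compound 1 to compound 2, a step that the two limits leave unreadable from compound 1 to compound 3 and a step that the two limits leave unreadable from compound 2 to compound 3; each is left unreadable by the two limits, so none gives a size in either direction. Chloro, ethynyl, fluoro and hydrogen on that ring all leave the read-out at the limit, and methyl is a change of the same kind on the same ring. The expectation is therefore no step beyond the scatter, a step that the limit leaves unreadable from compound 3 to compound 4, with compound 4 expected to stay at the limit. Compound 4 is estimated at 60000 nM, within 20000 nM to 200000 nM, and most likely reported again only as a limit.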

Compound 4, half-maximal inhibitory concentration: > 40000 nM
Compound 4: only a limit was reported; the forecaster's own chance of this, stated with the estimate: 85%; the middle value is on the limit's open side.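

In this assay compound 4 returns only a limit, > 40000 nM. No new step can be read between compound 4 and compounds 1, 2 and 3, because all four stand at the same limit: the limit of > 40000 nM in this assay, at which 4 of the 4 values shown sit.

From the compounds shown here alone, how far each of the four compounds lies beyond that limit, and whether any change on this ring moves the read-out, stays open.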